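A few compounds are considered here, and "the series" means these few. Any claim that something is new, unique, unknown or untested is made for them only; others in the source may bear on it.

Compound 1 `COc1ccccc1-c1cn(C[C@H](O)[C@H]2OC(=O)C(OCc3ccccc3)=C2OCc2ccccc2)nn1` and compound 2 `O=C1O[C@H]([C@@H](O)Cn2cc(-c3cc(F)cc(F)c3)nn2)C(OCc2ccccc2)=C1OCc1ccccc1` share one core and differ only in the aryl group on the triazole carbon. In a functional assay on SW-620 cells (Homo sapiens) for antiproliferative activity, read by MTT assay, with a stated time of 72 h (a lower number here means a stronger inhibitor, a higher number a weaker inhibitor), compound 1 reaches only the assay limit, > 100000 nM. In this assay compound 2 likewise sits at the limit, > 100000 nM. The step that the two limits leave unreadable from compound 1 to compound 2 is therefore not readable. Compound 3 `COc1ccc(-c2cn(C[C@H](O)[C@H]3OC(=O)C(OCc4ccccc4)=C3OCc3ccccc3)nn2)cc1` differs from compound 2 by 4-methoxyphenyl in place of 3,5-difluorophenyl on an aromatic carbon. Within the data shown here, both measured values sit at the limit of > 100000 nM in this assay, at which 2 of the 2 values shown sit, so no measured step sets a size for this change. Compound 3 is expected to stay at the limit, with an estimated 150000 nM (range 50000 nM to 500000 nM). The expected step is a step that the limit leaves unreadable from compound 2 to compound 3.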

Compound 3, half-maximal inhibitory concentration: 58200 nM
Compound 3: the middle estimate sits 2.6-fold (0.41 log units) above what was measured; the range from low to high includes it.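

In this assay, among these compounds, compound 3, carrying 4-methoxyphenyl, gives 58200 nM, the only value shown at this aromatic carbon that is not a limit: the limit of > 100000 nM in this assay, at which 2 of the 3 values shown sit. Placing 4-methoxyphenyl there in place of 3,5-difluorophenyl gives an at least 1.7-fold lower number from compound 2 to compound 3 (0.23 log units; that floor lies within the scatter), and placing it there in place of 2-methoxyphenyl gives an at least 1.7-fold lower number from compound 1 to compound 3 (0.23 log units; that floor lies within the scatter). Both figures are floors within the scatter, so neither change is shown to exceed it.

The step between compound 1 and compound 2 cannot be read. From the compounds shown here alone, whether an amine or a carboxylic acid on this aryl ring would give a step beyond the scatter remains open.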